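A few compounds are considered here, and "the series" means these few. Any claim that something is new, unique, unknown or untested is made for them only; others in the source may bear on it.

Compound 1 `CN1CCN(c2ccc(S(=O)(=O)Oc3cccc(Br)c3)cc2)C1=O`: 1300 nM
Compound 2 `CN1CCN(c2ccc(S(=O)(=O)Oc3cccc([N+](=O)[O-])c3)cc2)C1=O`: 26000 nM
Compound 3 `CCN1CCN(c2ccc(S(=O)(=O)Oc3cccc(Br)c3)cc2)C1=O`: not yet measured

Going by the values given here, in a functional assay on HT-29 cells (Homo sapiens) for antiproliferative activity, read by sulforhodamine B assay, with a stated time of 48 h (a higher number here means a weaker inhibitor, a lower number a stronger inhibitor), compound 1 gives 1300 nM, the lower of the two numbers so far. Compound 3 differs from it by methyl in place of hydrogen on a saturated chain carbon bound to an amide-type nitrogen in a ring, which reads as methyl to ethyl. Among the compounds with values here, the only measured step, a 20-fold higher number from compound 1 to compound 2 (1.30 log units; beyond the scatter), is large, but it is a nitro in place of bromo on an aromatic carbon, so it does not touch this place and bears on the change only loosely. No shift beyond the scatter is therefore expected, and no direction can be favoured. The expected step is a 1.1-fold higher number from compound 1 to compound 3 (0.03 log units; within the scatter). The estimate for compound 3 is 1400 nM, with an estimated range of 550 nM to 3500 nM.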

Compound 3, half-maximal inhibitory concentration: 3800 nM
The estimate for compound 3 lay 2.7-fold (0.43 log units) below the measured number; measured number outside the range, above it.
By their numbers in this assay, from the lowest: compound 1; then compound 3; then compound 2.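

In this assay, this place proves sensitive to a small change: methyl to ethyl, one added carbon on the chain bound to an amide-type nitrogen in a ring, gives a 2.9-fold higher number from compound 1 to compound 3 (0.47 log units; beyond the scatter) and so a weaker inhibitor, though the step is modest. Going by these compounds alone, the earlier pair spoke only of bromo and nitro on an aromatic carbon, so this is the first reading of this place. Nothing available gives a reason for the step.

On these data alone, it remains open whether a longer chain such as propyl would weaken activity further, and how the amide hydrogen or a hydroxyethyl group would compare with methyl.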